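The source may report more compounds than this note shows. Statements on the series, on what has been measured and on what is new or still open speak of the compounds shown alone.

Compounds measured so far:
compound 1, `Cc1ccccc1Nc1nc(Nc2ccc(N3CCN(C)CC3)cc2)ncc1Cl` — 13700 nM
compound 2, `Cc1ccccc1Nc1nc(Nc2ccc(N3CCN(C(=O)OC(C)(C)C)CC3)cc2)ncc1Cl` — 5120 nM
compound 3, `CN1CCN(c2ccc(Nc3ncc(Cl)c(NCc4ccccc4)n3)nc2)CC1` — > 100000 nM
compound 4, `COc1ccc(Nc2nc(Nc3ccc(N4CCN(C)CC4)cn3)ncc2Cl)cc1` — not yet measured

In a functional assay on Jurkat cells (Homo sapiens) for inhibition, read by CCK-8 assay, with a stated time of 48 h (on this read-out lower numbers stand for stronger inhibition of growth and higher numbers for weaker inhibition of growth), compound 1 gives 13700 nM. Within the data shown here, compound 2 gives 5120 nM in this assay, and the step of a 2.7-fold lower number from compound 1 to compound 2 (0.43 log units; beyond the scatter) is the only measured step in this set. Compound 3 stands apart: in this assay compound 3 reaches only > 100000 nM, which is a limit of the assay and not a number (the limit of > 100000 nM in this assay, at which 1 of the 3 values shown sits).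

Compound 4 differs from compound 3 by 4-methoxyphenyl in place of benzyl on a nitrogen on an aromatic ring. The measured step of a 2.7-fold lower number from compound 1 to compound 2 (0.43 log units; beyond the scatter) concerns the amine nitrogen in the piperazine ring and does not touch the nitrogen where compound 4 changes, so it gives no direct guide to this step. What the values do show is that compounds 1 and 2, each carrying an aromatic ring directly on that nitrogen, return numbers in this assay, while compound 3 with its benzyl does not. Compound 4 is therefore expected to move back into the measurable range, with an estimate of 15000 nM (from 4000 nM to 60000 nM). That estimate means a step of an at least 6.6-fold lower number from compound 3 to compound 4 (0.82 log units; beyond the scatter) is expected.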

Compound 4, concentration for 50% growth inhibition: 11200 nM
Estimate against measurement, compound 4: 1.3-fold (0.13 log units) above; the range from low to high includes it.
By their numbers in this assay, from the lowest: compound 2; then compounds 4 and 1 (each within the scatter of the next). At a limit, above all of these: compound 3.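

On the nitrogen on an aromatic ring, the first change measured at this position, 4-methoxyphenyl in place of benzyl, gives in this assay an at least 8.9-fold lower number from compound 3 to compound 4 (0.95 log units; beyond the scatter). The group on this nitrogen can therefore decide whether a compound returns a number in this assay at all, and compound 4 gives 11200 nM. Compound 3 stands at a limit of the assay and not at a number, so the step gives only a bound on the size of this change: the limit of > 100000 nM in this assay, at which 1 of the 4 values shown sits.

This single pair cannot separate the replacement of benzyl by an aryl group from the presence of the methoxy group, and a plain phenyl or a 4-methoxybenzyl group on this nitrogen would be needed to tell them apart. As far as these compounds go, how a hydroxyl or an amine in place of that methoxy group would read also remains open.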